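The source may hold more compounds than are shown below. What is called first, only, known or untested is meant among the compounds shown, and "the series" means these compounds.

Measured compounds:
- Compound 1 `CNCC(=O)Nc1cc(OC)ccc1C(=O)c1ccc(OC)c2c1OC(C)(C)C=C2`: in a functional assay on A2780 cells (Homo sapiens) for antiproliferative activity, read by MTT assay, with a stated time of 48 h (on this read-out higher numbers stand for weaker inhibition and lower numbers for stronger inhibition), compound 1 gives 620 nM
- Compound 2 `CNCC(=O)Nc1cc(OC)ccc1C(=O)c1ccc2c(c1)C=CC(C)(C)O2`: compound 2 gives 850 nM
- Compound 3 `CCNCC(=O)Nc1cc(OC)ccc1C(=O)c1ccc(OC)c2c1OC(C)(C)C=C2`: compound 3 gives 1980 nM

Compound 1 and compound 2 carry different cores; how the two cores differ is not broken down here, and their two values lie within the usual scatter of each other. Compound 3 arises from compound 1 by one change, (methyl in place of hydrogen on a saturated chain carbon bound to an amine nitrogen), and this step, a 3.2-fold higher number from compound 1 to compound 3 (0.50 log units; beyond the scatter), weakened inhibition. Compound 4 `CCNCC(=O)Nc1cc(OC)ccc1C(=O)c1ccc2c(c1)C=CC(C)(C)O2` is not yet measured; it arises from compound 2 by the same change, (methyl in place of hydrogen on a saturated chain carbon bound to an amine nitrogen), at the same place. Among the compounds with values here, because the only precedent is a 3.2-fold higher number from compound 1 to compound 3 (0.50 log units; beyond the scatter), a step of similar size, a 3.1-fold higher number from compound 2 to compound 4 (0.49 log units; beyond the scatter), is expected here, though it rests on a single pair. Compound 4 is therefore estimated at 2600 nM, with a plausible range from 1300 nM to 5500 nM.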

Compound 4, half-maximal inhibitory concentration: 2070 nM
Compound 4: the middle estimate sits 1.3-fold (0.10 log units) above what was measured; the measured number falls inside the stated range.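

In this assay, replacing methylamino with ethylamino on this core gives a 2.4-fold higher number from compound 2 to compound 4 (0.39 log units; beyond the scatter) and so weakens inhibition here too. Set beside the earlier step, the change behaves alike on both cores: the same change on two cores in this assay, a 3.2-fold higher number (0.50 log units; beyond the scatter) from compound 1 to compound 3 and a 2.4-fold higher number (0.39 log units; beyond the scatter) from compound 2 to compound 4, 1.3-fold (0.12 log units) apart, within the scatter of two such steps. This shows that the change carried over between these two cores in this one cell assay, but it does not show that it would carry over to any further core, and it gives no reason for the weakening.

The compounds shown leave open whether a longer chain such as propyl, or a branched one such as isopropyl, would weaken inhibition further. They also leave open what a primary amine or a cyclic amine such as pyrrolidine would do.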